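Swapping 1-benzofuran-2-yl for iodo

A few compounds are considered here, and "the series" means these few. Any claim that something is new, unique, unknown or untested is made for them only; others in the source may bear on it.

Measured in a functional assay on CCRF-CEM cells (Homo sapiens), read by MTT assay, with a stated time of 72 h; a lower number here means a stronger inhibitor, a higher number a weaker inhibitor:
Compound 1 `Cc1nc(N)c2c(-c3ccco3)cn([C@@H]3O[C@H](CO)[C@@H](O)[C@H]3O)c2n1`: > 100000 nM (a limit)
Compound 2 `Cc1nc(N)c2c(-c3cc4ccccc4o3)cn([C@@H]3O[C@H](CO)[C@@H](O)[C@H]3O)c2n1`: > 20000 nM (a limit)

Compound 2 gives > 20000 nM, which is a limit and not a number. Compound 3 `Cc1nc(N)c2c(I)cn([C@@H]3O[C@H](CO)[C@@H](O)[C@H]3O)c2n1` carries iodo in place of 1-benzofuran-2-yl on an aromatic carbon. Going by the values given here, one measured step bears on this, the exchange of groups on that same carbon, a step that the two limits leave unreadable from compound 1 to compound 2. It has no readable size, so it offers no measure for the new change. Neither compound with a ring at this place has yet given a number in this assay. Compound 3 has no ring there, so a modest move towards stronger inhibition is expected, although another limit is quite possible. The expected step is an at least 1.3-fold lower number from compound 2 to compound 3 (0.12 log units; that floor lies within the scatter). For compound 3 the estimated value is 15000 nM, with an expected range from 2000 nM to 100000 nM.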

Compound 3, half-maximal inhibitory concentration: 9030 nM
Compound 3: middle estimate off by 1.7-fold (0.22 log units), on the high side, within the range that was stated.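

In this assay, this carbon turns out to be able to change the read-out: iodo in place of the rings gives an at least 2.2-fold lower number from compound 2 to compound 3 (0.34 log units; beyond the scatter), and against the smaller ring it gives an at least 11-fold lower number from compound 1 to compound 3 (1.04 log units; beyond the scatter). The first of these is a floor and not an exact size, because the value of compound 2 is a limit: the limit of > 20000 nM in this assay, at which 1 of the 3 values shown sits. The second is a floor for the same reason, as the value of compound 1 is also a limit: the limit of > 100000 nM in this assay, at which 1 of the 3 values shown sits.

The step between compound 1 and compound 2 cannot be read, so nothing is known about how the two rings compare with each other. From the compounds shown here alone, it also remains open whether iodo itself matters or simply the absence of a ring, which a bromo, a chloro or a plain methyl group on the same carbon could help to separate.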